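The compounds below may be only part of what the source reports. "The series", "measured", "known", "first", "only" and "open" are said of these compounds alone.

In an ADME assay on microsomes from liver (Mus musculus, strain CD-1) for metabolic stability, read by LC-MS, tested at 2 uM (on this read-out lower numbers stand for a shorter-lived compound and higher numbers for a longer-lived compound), compound 1 `Cn1cc(CNC(=O)c2ccncc2Nc2cc(-c3ccc4ccn(C)c4c3)c3nccnc3c2)cn1` gives 0.267 h. Compound 2 `Cn1ccc2ccc(-c3cc(Nc4cnccc4C(=O)NC4CCNC(=O)C4)cc4nccnc34)cc21` is reported as > 1 h, which is a limit of the assay and not a number.

Within the data shown here, the only measured step between compounds differing in one place is an at least 3.7-fold higher number from compound 1 to compound 2 (0.57 log units; beyond the scatter). It came with 2-oxopiperidin-4-yl in place of (1-methyl-1H-pyrazol-4-yl)methyl on an amide-type nitrogen, and it lies beyond the scatter.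

Compound 3 `CC(=O)N1CCCC(NC(=O)c2ccncc2Nc2cc(-c3ccc4ccn(C)c4c3)c3nccnc3c2)C1`, not yet measured, changes that same place again, with 1-acetylpiperidin-3-yl in place of 2-oxopiperidin-4-yl on an amide-type nitrogen. Both groups hold one six-membered non-aromatic ring with 1 hetero atom, so the new swap is expected to be milder than the replacement in an at least 3.7-fold higher number from compound 1 to compound 2 (0.57 log units; beyond the scatter), though that single step is thin support. The half-life of compound 3 is therefore expected to stay nearer the top of the range seen so far, with a small drop as the likeliest outcome.

The expected change is an at least 1.4-fold lower number from compound 2 to compound 3 (0.15 log units; that floor lies within the scatter), and its size is uncertain given the limit.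

For compound 3 the estimate is 0.7 h, with an expected range from 0.27 h to 1.8 h.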

Compound 3, half-life: 0.4 h
Beside the measured number, compound 3's estimate is 1.8-fold (0.24 log units) above it, within the range that was stated.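

At this amide-type nitrogen in this assay, a six-membered non-aromatic ring with 1 hetero atom is not enough on its own to keep the higher number, since 1-acetylpiperidin-3-yl in place of 2-oxopiperidin-4-yl gives an at least 2.5-fold lower number from compound 2 to compound 3 (0.39 log units; beyond the scatter). The comparison with the pyrazole-bearing group gives a 1.5-fold higher number from compound 1 to compound 3 (0.18 log units; within the scatter), so 1-acetylpiperidin-3-yl and (1-methyl-1H-pyrazol-4-yl)methyl cannot be told apart here, and only 2-oxopiperidin-4-yl stands out among the three groups. The full size of the drop stays unknown because compound 2 is given only as a limit of the assay, not a number: the limit of > 1 h in this assay, at which 1 of the 3 values shown sits.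

The swap from compound 2 to compound 3 alters several features at once, including the hydrogen-bond donor count, the heavy-atom count and the way the ring is built, so these compounds cannot show which feature matters. A 1-acetylpiperidin-4-yl group, or a piperidine ring with a free amine in place of the acetyl, would help to separate the effect of the attachment point from that of the acetyl group.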